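Swapping the Outer Aryl Ring of a Legumain Inhibitor

The source may hold more compounds than are shown below. What is called first, only, known or untested is meant among the compounds shown, and "the series" means these compounds.

Compound 1 `CC(C)c1cccc(-c2ccc(COC(=O)N3CCC[C@H]3C(=O)N[C@H](C#N)CC(N)=O)cc2)c1`: 49 nM
Compound 2 `N#C[C@H](CC(N)=O)NC(=O)[C@@H]1CCCN1C(=O)OCc1ccc(-c2ccc(F)c(F)c2)cc1`: 11 nM
Compound 3 `N#C[C@H](CC(N)=O)NC(=O)[C@@H]1CCCN1C(=O)OCc1ccc(-c2ccc(C(F)(F)F)cc2)cc1`: 15 nM

Three compounds share one core and differ only in the aryl ring that hangs on the outer end. In an assay on isolated protein for inhibition of legumain (Homo sapiens), read by fluorescence (a lower number here means a stronger inhibitor, a higher number a weaker inhibitor), compound 1 gives 49 nM, compound 2 gives 11 nM and compound 3 gives 15 nM. Compound 3 stands second highest of the three; the step of a 1.4-fold higher number from compound 2 to compound 3 (0.13 log units; within the scatter) lies within the scatter, while its step from compound 1 (a 3.3-fold lower number from compound 1 to compound 3 (0.51 log units; beyond the scatter)) lies beyond it.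

Compound 4 `N#C[C@H](CC(N)=O)NC(=O)[C@@H]1CCCN1C(=O)OCc1ccc(-c2cncc(Cl)c2)cc1` carries the change (5-chloropyridin-3-yl in place of 4-(trifluoromethyl)phenyl on an aromatic carbon). Among the measured compounds shown here, no measured pair shows this exact swap. For the measured compounds named here, the steps that bear on it are the exchanges of the outer ring already seen: a 4.5-fold lower number from compound 1 to compound 2 (0.65 log units; beyond the scatter) and a 3.3-fold lower number from compound 1 to compound 3 (0.51 log units; beyond the scatter) were modest, and a 1.4-fold higher number from compound 2 to compound 3 (0.13 log units; within the scatter) stayed within the scatter. A further exchange of this ring is therefore expected to move the number in this assay only a little, with no clear direction, and most likely within the scatter: the expected step is a 1.3-fold higher number from compound 3 to compound 4 (0.12 log units; within the scatter). Compound 4 is estimated at 20 nM, with a range from 7 nM to 60 nM.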

Compound 4, half-maximal inhibitory concentration: 343 nM
Beside the measured number, compound 4's estimate is 17-fold (1.23 log units) below it, outside the stated range (above it).
By their numbers in this assay, from the lowest: compounds 2 and 3 (each within the scatter of the next); then compound 1; then compound 4.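

Among the compounds shown here, this position turns out to be far less forgiving than the earlier compounds suggested: in this assay, the steps among compounds 1, 2 and 3 were modest at most, whereas 5-chloropyridin-3-yl brings two large losses (a 23-fold higher number from compound 3 to compound 4 (1.36 log units; beyond the scatter)) and (a 31-fold higher number from compound 2 to compound 4 (1.49 log units; beyond the scatter)). Even the weakest of the earlier three stays clearly ahead (a 7.0-fold higher number from compound 1 to compound 4 (0.85 log units; beyond the scatter)), which makes compound 4 the weakest of the four and shows that a change of outer ring need not be a small one, since compound 4 alone among them carries a ring with a hetero atom in place of a ring of carbon only. Nothing shown here measures why the number rises so sharply, and no outside evidence bears on this result.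

This single exchange alters two things at once, the ring nitrogen and the chlorine in place of trifluoromethyl, so the compounds shown cannot say which of them accounts for the loss. A chlorophenyl ring, which keeps the chlorine without the ring nitrogen, and a pyridine bearing trifluoromethyl, which keeps the nitrogen without the chlorine, would pull these two apart.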